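The source may report more compounds than this note shows. Statements on the series, on what has been measured and on what is new or still open speak of the compounds shown alone.

Of the compounds shown here, three have been tested in a functional assay on MCF7 cells (Homo sapiens) for cytotoxicity, read by MTT assay, with a stated time of 24 h; a lower number here means a stronger inhibitor, a higher number a weaker inhibitor. Compound 1, `O=C(CN1CCN(c2ccc([N+](=O)[O-])cc2)CC1)N1CCN(c2nnc(-c3ccccc3)c(-c3ccccc3)n2)CC1`, gives only a limit of the assay rather than a number, > 886000 nM, as noted in the limit of > 886000 nM in this assay, at which 1 of the 3 values shown sits. Compound 2, `COc1ccc(N2CCN(CC(=O)N3CCN(c4nnc(-c5ccc(C)cc5)c(-c5ccc(C)cc5)n4)CC3)CC2)cc1`, gives 53000 nM in this assay. Compound 3, `COc1ccc(-c2nnc(N3CCN(C(=O)CN4CCN(c5ccccc5OC)CC4)CC3)nc2-c2ccc(OC)cc2)cc1`, likewise reaches only a limit of the assay, > 821000 nM, as noted in the limit of > 821000 nM in this assay, at which 1 of the 3 values shown sits. So compound 3 stands at a limit, one of two such limits among the three values, and nothing shows it as a measured inhibitor. Compound 4, `COc1ccc(-c2nnc(N3CCN(C(=O)CN4CCN(c5cccc(Cl)c5)CC4)CC3)nc2-c2ccc(OC)cc2)cc1`, differs from compound 3 in one place: 3-chlorophenyl in place of 2-methoxyphenyl on an amine nitrogen in a ring. Within the data shown here, with no measured step to draw on, no shift beyond the usual scatter is expected, so the step of an at least 1.6-fold lower number from compound 3 to compound 4 (0.21 log units; that floor lies within the scatter) is an estimate, and compound 4 is expected at about 500000 nM, within 80000 nM to 1000000 nM.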

Compound 4, half-maximal inhibitory concentration: > 814000 nM
Compound 4 was reported as a limit; the forecaster's own chance of this, stated with the estimate: 60%; at least 1.6-fold (0.21 log units) between middle value and limit.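

Compound 3 and compound 4 both give only limits of the assay rather than numbers, so the step between them cannot be read. The compounds shown leave open whether swapping 2-methoxyphenyl for 3-chlorophenyl changes cytotoxicity at all.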